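The compounds below may be only part of what the source reports. "The series", "measured", "known", "first", "only" and "open" are said of these compounds alone.

Among the compounds with values here, compound 1 `O=C(NCCCCc1ccccc1)c1cccc(C2SCC(=O)N2c2ccccc2)c1` gives 60% in a functional assay on 143B cells (Homo sapiens) for inhibition, read by CCK-8 assay, with a stated time of 72 h, tested at 1 uM (on this read-out lower numbers stand for less inhibition and higher numbers for more inhibition at the one concentration tested (going by the name of the read-out)), the higher of the two numbers measured so far; compound 2 `CCN1C(=O)CSC1c1cccc(C(=O)NCCCCc2ccccc2)c1` gives 40% in this assay. Within the data shown here, the only measured step, a number 20 percentage points lower from compound 1 to compound 2 (beyond the scatter), comes from ethyl in place of phenyl on an amide-type nitrogen in a ring, a different kind of change. Compound 3 `O=C(NCCCCc1ccccc1)c1cccc(C2SCC(=O)N2c2ccccc2F)c1` differs from compound 1 by fluoro in place of hydrogen on an aromatic carbon. Among the measured compounds shown here, no measured step involves the phenyl itself, so nothing here bears directly on this change. The step expected in this assay, no change at the digits printed from compound 1 to compound 3 (within the scatter), is therefore none beyond the scatter. Compound 3 is estimated at 60%, within 42% to 76%.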

Compound 3, a percentage reported as inhibition, at one concentration (the size of the read-out at that concentration, not a potency): 59%
Compound 3: middle estimate off by 1 percentage points, on the high side; measured number inside the range.
By their numbers in this assay, from the lowest: compound 2; then compounds 3 and 1 (each within the scatter of the next).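

In this assay, fluoro in place of hydrogen on an aromatic carbon, ortho to a large group, gives a number 1 percentage points lower from compound 1 to compound 3 (within the scatter) and so leaves the read-out unmoved at this position. 2-Fluorophenyl in place of ethyl on the amide-type nitrogen in the ring gives a number 19 percentage points higher from compound 2 to compound 3 (beyond the scatter) and so keeps the gap first seen with phenyl. Nothing measured here speaks to the cause of either step. As far as these compounds go, whether chloro, methoxy or an amine at this same place would also stay within the scatter of compound 1 remains open.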